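Trimming the ester chain of a thiophene-bearing dihydropyrimidinone

The source may hold more compounds than are shown below. What is called first, only, known or untested is meant among the compounds shown, and "the series" means these compounds.

Measured compounds:
- Compound 1, `CC1=C(C(=O)OCC(C)C)C(c2cccs2)NC(=O)N1`: 25%
- Compound 2, `CCC(CC)OC(=O)C1=C(C)NC(=O)NC1c1cccs1`: 13%

Both compounds share one core and differ only in the ester group. In an assay on membranes from CHO cells for displacement of a labelled ligand from adenosine receptor A1 (Homo sapiens), read by scintillation counting, with a stated time of 60 min, tested at 1 uM (on this read-out lower numbers stand for less inhibition and higher numbers for more inhibition at the one concentration tested (going by the name of the read-out)), compound 1 gives 25%. Compound 2, with pentan-3-yl in place of isobutyl on an oxygen next to a carbonyl group, gives 13%, the lowest of the two numbers; the step of a number 12 percentage points lower from compound 1 to compound 2 (beyond the scatter) lies beyond the scatter.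

Compound 3, `CCC(C)OC(=O)C1=C(C)NC(=O)NC1c1cccs1`, has not yet been measured. It differs from compound 2 by hydrogen in place of methyl on a saturated chain carbon, two bonds along the chain from an oxygen next to a carbonyl group, so that the pentan-3-yl becomes sec-butyl. Going by the values given here, only the step of a number 12 percentage points lower from compound 1 to compound 2 (beyond the scatter) bears on this, and it shows that changing the ester chain can move the read-out by a modest amount. Removing one carbon from the chain of compound 2 is expected to undo part of that loss, so a small rise, a number 5 percentage points higher from compound 2 to compound 3 (within the scatter), is expected, probably within the scatter. The estimate for compound 3 is 18%, with a range from 5% to 32%.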

Compound 3, a percentage reported as inhibition, at one concentration (the size of the read-out at that concentration, not a potency): 5%
Compound 3: middle estimate off by 13 percentage points, on the high side, and the stated range covers the measured number.
By their numbers in this assay, from the lowest: compounds 3 and 2 (each within the scatter of the next); then compound 1.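

Hydrogen in place of methyl on this saturated chain carbon gives a number 8 percentage points lower from compound 2 to compound 3 (within the scatter) and so the read-out does not separate the pentan-3-yl ester from the sec-butyl ester. Sec-butyl in place of isobutyl on the same oxygen gives a number 20 percentage points lower from compound 1 to compound 3 (beyond the scatter) and so isobutyl now stands apart from both of the other chains, not just from pentan-3-yl. No measurement available here explains why isobutyl differs from these two chains.

On these data alone, it remains open whether a straight butyl chain, a longer chain or a carboxylic acid in place of the ester would raise or lower the read-out. Each number also comes from a single concentration, so the potency of these compounds remains open as well.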